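The compounds below may be only part of what the source reports. "The series", "measured", "known", "first", "only" and "open" are said of these compounds alone.

Notes on the urea series around the shared core of compound 1.

Compound 1 `CC(C)c1cccc(C(C)C)c1NC(=O)NCC1(c2ccccc2C(F)(F)F)CCCC1` gives 18 nM in an assay on microsomes for inhibition of acyl-CoA:cholesterol acyltransferase (Oryctolagus cuniculus); on this read-out higher numbers stand for weaker inhibition and lower numbers for stronger inhibition. Among the compounds with values here, compound 2 `CC(C)c1cccc(C(C)C)c1NC(=O)NCC1(c2ccc(C(F)(F)F)cc2)CCCC1` gives 66 nM in this assay; this is the highest of the two numbers measured so far, and the only step in hand, a 3.7-fold higher number from compound 1 to compound 2 (0.56 log units; beyond the scatter), separates it from compound 1.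

Compound 3 `CC(C)c1cccc(C(C)C)c1NC(=O)NCC1(c2ccc(CO)cc2)CCCC1` is not yet measured. It differs from compound 2 in one place: hydroxymethyl in place of trifluoromethyl on an aromatic carbon.

Within the data shown here, no measured pair shows this exchange of trifluoromethyl for hydroxymethyl; the single step in hand, a 3.7-fold higher number from compound 1 to compound 2 (0.56 log units; beyond the scatter), concerns only where the trifluoromethyl sits and gives no reading on its replacement. The expectation for this assay therefore rests on the value of compound 2 alone, with wide uncertainty in either direction; a step beyond the scatter cannot be ruled out, nor predicted with confidence. Compound 3 is estimated at 120 nM, within 35 nM to 450 nM, which means an expected step of a 1.8-fold higher number from compound 2 to compound 3 (0.26 log units; within the scatter).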

Compound 3, half-maximal inhibitory concentration: 26 nM
Compound 3: the middle estimate sits 4.6-fold (0.66 log units) above what was measured, outside the stated range (below it).
By their numbers in this assay, from the lowest: compounds 1 and 3 (each within the scatter of the next); then compound 2.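

On this aromatic carbon, trifluoromethyl is not required for inhibition in this assay: hydroxymethyl, which brings a hydrogen-bond donor and acceptor where trifluoromethyl has neither, gives a 2.5-fold lower number from compound 2 to compound 3 (0.40 log units; beyond the scatter) and so a modest gain over compound 2. Against the 2-(trifluoromethyl)phenyl group of compound 1, the 4-(hydroxymethyl)phenyl group gives a 1.4-fold higher number from compound 1 to compound 3 (0.16 log units; within the scatter) and so no readable difference, which means the weaker result seen in a 3.7-fold higher number from compound 1 to compound 2 (0.56 log units; beyond the scatter) belongs to 4-(trifluoromethyl)phenyl and not to every group carried at that place. The data on hand offer no measurement that explains this gain.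

Still open, from the compounds shown here alone, is whether the hydroxyl itself matters, a question that methoxymethyl, aminomethyl or a carboxylic acid on the same aromatic carbon could address, while a longer chain such as hydroxyethyl would show how much length this place accepts. Also open, going by these compounds, is how hydroxymethyl would fare in place of the trifluoromethyl of compound 1, and whether the two placements of a group would then differ as they do for trifluoromethyl.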